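Arylthio enones on DU-145 growth: a benzyl swap

This account rests on a few compounds, and the source may have more. Where it says the series, first, only, none or still open, it means among the compounds named here.

Measured so far:
compound 1 `Cc1ccc(S/C(=C/c2ccc(N(C)C)cc2)C(=O)c2ccc(Cl)cc2)cc1` gives > 100000 nM
compound 2 `CN(C)c1ccc(/C=C(/SCc2ccccc2Cl)C(=O)c2ccc(Cl)cc2)cc1` gives > 100000 nM
compound 3 `Cc1ccc(S/C(=C/c2ccc(Oc3ccccc3)cc2)C(=O)c2ccc(Cl)cc2)cc1` gives 10000 nM

In a functional assay on DU-145 cells (Homo sapiens) for inhibition, read by trypan blue exclusion, with a stated time of 96 h (a higher number here means a weaker inhibitor of growth, a lower number a stronger inhibitor of growth), compound 1 reaches only a limit, > 100000 nM, and no number. Compound 2 likewise sits at a limit, > 100000 nM. Of the three, only compound 3 returns a number, 10000 nM. The change 2-chlorobenzyl in place of 4-methylphenyl on a sulfur therefore gives a step that the two limits leave unreadable from compound 1 to compound 2, since both ends rest at the limit of > 100000 nM in this assay, at which 2 of the 3 values shown sit. The change phenoxy in place of dimethylamino on an aromatic carbon gives an at least 10-fold lower number from compound 1 to compound 3 (1.00 log units; beyond the scatter), though the starting point is itself a limit.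

Compound 4 `O=C(/C(=C\c1ccc(Oc2ccccc2)cc1)SCc1ccccc1Cl)c1ccc(Cl)cc1` is the unmeasured member. It differs from compound 3 by 2-chlorobenzyl in place of 4-methylphenyl on a sulfur, the same change as from compound 1 to compound 2, at a place described in the same words. Since that earlier step could not be read, nothing measured fixes its size here. For compound 4 a step of a 1.2-fold higher number from compound 3 to compound 4 (0.08 log units; within the scatter) is expected, resting on compound 3 at 10000 nM as the only numbered anchor. Compound 4 is estimated at 12000 nM, with a wide range from 2000 nM to 100000 nM.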

Compound 4, concentration for 50% growth inhibition: 1000 nM
Compound 4: middle estimate off by 12-fold (1.08 log units), on the high side, and the stated range ends above it.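

Working notes: with phenoxy on the shared core, 2-chlorobenzyl in place of 4-methylphenyl on a sulfur gives a 10-fold lower number from compound 3 to compound 4 (1.00 log units; beyond the scatter) in this assay, so on this core the swap has a readable size. Phenoxy in place of dimethylamino gives an at least 100-fold lower number from compound 2 to compound 4 (2.00 log units; beyond the scatter), and the direction matches on both cores, but a single size for this change is not established: the same change on two cores in this assay, an at least 10-fold lower number (1.00 log units; beyond the scatter) from compound 1 to compound 3 and an at least 100-fold lower number (2.00 log units; beyond the scatter) from compound 2 to compound 4; the limit leaves it open whether they differ The same sulfur swap between compound 1 and compound 2 cannot be read, so the data do not show that its effect on compound 3 carries over to the dimethylamino core, and the steps that touch this ceiling give no exact sizes: the limit of > 100000 nM in this assay, at which 2 of the 4 values shown sit.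

Still open, on these data alone, is whether the result for compound 4 depends on the chlorine of the 2-chlorobenzyl group or would also appear with plain benzyl on the sulfur. The compounds shown also leave open how a carboxylic acid or a longer chain in place of phenoxy would read in this assay.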